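This account rests on a few compounds, and the source may have more. Where it says the series, first, only, none or still open, it means among the compounds named here.

In a functional assay on cells (Cancer cell lines, Homo sapiens) for cytotoxicity, read by sulforhodamine B assay, with a stated time of 48 h (a higher number here means a weaker inhibitor of growth, a lower number a stronger inhibitor of growth), compound 1 `O=C1N=C(N2N=C(c3ccccc3)CC2c2ccccc2O)S/C1=C1/C(=O)Nc2ccc(Br)cc21` gives 630 nM, compound 2 `COc1ccc(C2CC(c3ccccc3)=NN2C2=NC(=O)/C(=C3\C(=O)Nc4ccccc43)S2)cc1` gives 4270 nM, and compound 3 `COc1ccc(C2CC(c3ccccc3)=NN2C2=NC(=O)/C(=C3\C(=O)Nc4ccc(Br)cc43)S2)cc1` gives 360 nM. Compound 3 has the lowest of the three numbers: a 1.8-fold lower number from compound 1 to compound 3 (0.24 log units; within the scatter), while a 12-fold lower number from compound 2 to compound 3 (1.07 log units; beyond the scatter). Compound 4 `COc1ccc(C2CC(c3ccc4ccccc4c3)=NN2C2=NC(=O)/C(=C3\C(=O)Nc4ccc(Br)cc43)S2)cc1` differs from compound 3 by naphthalen-2-yl in place of phenyl on a carbon with a double bond to nitrogen. Neither measured step touches this part of the shared core; one swaps the group on a saturated ring carbon, the other adds bromo on an aromatic carbon, so nothing shown tells how a larger group at this place acts. For compound 4 the expected step is a 1.1-fold higher number from compound 3 to compound 4 (0.05 log units; within the scatter), with no shift beyond the scatter foreseen. Compound 4 is estimated at 400 nM, within 150 nM to 1200 nM.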

Compound 4, concentration for total growth inhibition: 330 nM
Beside the measured number, compound 4's estimate is 1.2-fold (0.08 log units) above it; the measured number falls inside the stated range.
By their numbers in this assay, from the lowest: compounds 4, 3 and 1 (each within the scatter of the next); then compound 2.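

In this assay, naphthalen-2-yl in place of phenyl on the carbon with a double bond to nitrogen gives a 1.1-fold lower number from compound 3 to compound 4 (0.04 log units; within the scatter). For the compounds shown here, this is the first measured change at this place, and it shows that the number holds when the phenyl gives way to a group of 2 six-membered aromatic rings. Nothing measured here explains why the two compounds read alike.

Going by these compounds, whether an amine or a carboxylic acid at this place would leave the number unchanged remains open. So does whether a methyl group, far smaller than phenyl, would do so.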